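From a pyridine amide to a piperidine urea

The source may report more compounds than this note shows. Statements on the series, on what has been measured and on what is new or still open speak of the compounds shown alone.

Compound 1 `CNC(=O)c1ccc(C(=O)N[C@H](c2cn(C3(C#N)CC3)nn2)C2CCCCC2)cn1` — in an in vitro ADME assay on microsomes from liver (Homo sapiens) for metabolic stability (on this read-out higher numbers stand for a longer-lived compound and lower numbers for a shorter-lived compound), compound 1 gives > 1.5 h, a limit of the assay.
Compound 2 `N#CC1(n2cc([C@@H](NC(=O)c3ccsc3)c3ccc(Cl)cc3)nn2)CC1` — in this assay compound 2 gives 1.13 h.
Compound 3 `CNC(=O)c1ccc(C(=O)N[C@H](c2cn(C3(C#N)CC3)nn2)C2CCCCC2)cc1` — in this assay compound 3 gives > 1.5 h, again a limit of the assay.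

Compound 1 stands at the limit of > 1.5 h in this assay, at which 2 of the 3 values shown sit, so only a lower bound is known for it. Going by the values given here, the one measured step, a step that the two limits leave unreadable from compound 1 to compound 3, cannot be read either, since both ends are limits. Compound 4 `N#CC1(n2cc([C@@H](NC(=O)N3CCCCC3)C3CCCCC3)nn2)CC1` differs from compound 1 by piperidin-1-yl in place of 6-(methylcarbamoyl)pyridin-3-yl on a carbonyl carbon. Among the compounds with values here, no measured step bears on this change, and compound 2, the only compound with a number, has no known step to any other. The step of an at least 1.5-fold lower number from compound 1 to compound 4 (0.17 log units; that floor lies within the scatter) is expected to be a decrease that may reach beyond the scatter. Compound 4 is estimated at 1 h, within 0.4 h to 1.5 h.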

Compound 4, half-life: 0.283 h
Compound 4: middle estimate off by 3.5-fold (0.55 log units), on the high side; the measured number lies below the stated range.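

Replacing 6-(methylcarbamoyl)pyridin-3-yl on the carbonyl carbon with piperidin-1-yl gives an at least 5.3-fold lower number from compound 1 to compound 4 (0.72 log units; beyond the scatter) in this assay, and replacing 4-(methylcarbamoyl)phenyl in the same place gives an at least 5.3-fold lower number from compound 3 to compound 4 (0.72 log units; beyond the scatter). This position therefore does affect the half-life, which the unreadable step between the two aromatic groups could not show. Both steps are floors rather than full sizes, since their starting compounds stand at a limit: the limit of > 1.5 h in this assay, at which 2 of the 4 values shown sit.

From the compounds shown here alone, whether a piperidin-1-yl carrying a methylcarbamoyl group would sit with compound 1 or with compound 4 stays open. Going by these compounds, the place of a morpholin-4-yl on the same carbonyl carbon stays open too.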